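This account rests on a few compounds, and the source may have more. Where it says the series, first, only, none or still open, it means among the compounds named here.

Within the data shown here, compound 1 `Cc1ncnc2c1c(I)cn2[C@@H]1O[C@H](CO)[C@@H](O)[C@H]1O` is one of only two compounds measured in a functional assay on HCT-116 cells (Homo sapiens), read by MTT assay, with a stated time of 72 h; a higher number here means a weaker inhibitor, a lower number a stronger inhibitor. In this assay compound 1 gives 4720 nM, the highest of the two numbers. Among the measured compounds shown here, the other, compound 2 `COc1ncnc2c1c(-c1ccoc1)cn2[C@@H]1O[C@H](CO)[C@@H](O)[C@H]1O`, gives 110 nM in this assay, a much lower number, beyond the usual scatter; compound 2 differs from compound 1 in more than one place, so no single step between them is counted. The unmeasured compound 3 `Cc1ncnc2c1c(-c1cc3ccccc3o1)cn2[C@@H]1O[C@H](CO)[C@@H](O)[C@H]1O` keeps the core of compound 1 and differs from it in one place: 1-benzofuran-2-yl in place of iodo on an aromatic carbon. For the measured compounds named here, no measured pair isolates this change. Compound 1 carries iodo where compound 2 carries an aromatic ring, and compound 2 gives 110 nM. On that basis a step toward a lower number is expected, of about a 7.9-fold lower number from compound 1 to compound 3 (0.90 log units; beyond the scatter). Compound 3 is therefore estimated at 600 nM in this assay, within a range from 120 nM to 3000 nM.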

Compound 3, half-maximal inhibitory concentration: > 20000 nM
Compound 3: only a limit was reported; the forecaster's own chance of this, stated with the estimate: 5%; middle value at least 33-fold (1.52 log units) away from the limit.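

On this aromatic carbon of the core of compound 1, 1-benzofuran-2-yl in place of iodo does not lower the number in this assay; the change gives an at least 4.2-fold higher number from compound 1 to compound 3 (0.62 log units; beyond the scatter). This single-place step shows that carrying an aromatic ring system here is not enough for a low number, something the earlier pair, which differs in more than one place, could not show. The value of compound 3 is a limit and not a number, so the full size of the step cannot be read: the limit of > 20000 nM in this assay, at which 1 of the 3 values shown sits.

The compounds shown leave open whether a phenyl ring or an amine on this carbon, with the core of compound 1 kept, would give a lower or a higher number than iodo. They also leave open whether the same change would give a step of similar direction on the core of compound 2.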